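The compounds below may be only part of what the source reports. "The series", "measured", "known", "first", "only" and "open" are said of these compounds alone.

Compound 1 `COc1cc2c(Nc3ccc(C#N)cc3)ncnc2cc1OCCCN(C)Cc1ccccc1` is known in this study only by a limit: in a functional assay on DU-145 cells (Homo sapiens) for antiproliferative activity, read by MTT assay, with a stated time of 72 h (on this read-out lower numbers stand for stronger inhibition and higher numbers for weaker inhibition), compound 1 gives > 100000 nM, which is a limit of the assay and not a number. Compound 2 `COc1cc2c(Nc3ccc(C#N)cc3)ncnc2cc1OCCCN1CCC(O)CC1` gives 74900 nM in this assay. Compound 3 `COc1cc2c(Nc3ccc(C#N)cc3)ncnc2cc1OCCCN1CCC(c2ccccc2)CC1` gives 6790 nM in this assay. The measured steps run an at least 1.3-fold lower number from compound 1 to compound 2 (0.12 log units; that floor lies within the scatter) and an at least 14-fold lower number from compound 1 to compound 3 (1.16 log units; beyond the scatter); between the two piperidine compounds the step is an 11-fold lower number from compound 2 to compound 3 (1.04 log units; beyond the scatter).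

Compound 4 `COc1cc2c(Nc3ccc(C#N)cc3)ncnc2cc1OCCCN1CCC(N2CCCCC2)CC1` differs from compound 1 in one place: 4-(piperidin-1-yl)piperidin-1-yl in place of benzyl(methyl)amino on a saturated chain carbon, three bonds along the chain from an oxygen on an aromatic ring. The two steps out of compound 1 bear on this change, as both exchange the same group at the same place for a piperidine ring carrying a group on a saturated ring carbon. The first of those steps stays within the scatter, the second is large. A piperidin-1-yl on a saturated ring carbon is neither the hydroxy of compound 2 nor the phenyl of compound 3, so the step into compound 4 is expected to land between those two outcomes, toward a lower number. The expected step is an at least 5.0-fold lower number from compound 1 to compound 4 (0.69 log units; beyond the scatter), and compound 4 is estimated at 20000 nM, within a range from 5000 nM to 80000 nM.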

Compound 4, half-maximal inhibitory concentration: 15600 nM
Estimate against measurement, compound 4: 1.3-fold (0.11 log units) above; low and high end bracket the measured number.
By their numbers in this assay, from the lowest: compound 3; then compound 4; then compound 2. At a limit, above all of these: compound 1.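

Exchanging hydroxy for piperidin-1-yl on the saturated ring carbon gives a 4.8-fold lower number from compound 2 to compound 4 (0.68 log units; beyond the scatter), while exchanging phenyl for piperidin-1-yl gives a 2.3-fold higher number from compound 3 to compound 4 (0.36 log units; beyond the scatter). The group on this ring carbon therefore now sets three distinct levels in this assay, and a ring there does not by itself match phenyl, since the non-aromatic ring of compound 4 falls short of the aromatic ring of compound 3 by a modest step. The step out of the benzyl(methyl)amino compound, an at least 6.4-fold lower number from compound 1 to compound 4 (0.80 log units; beyond the scatter), is a floor and not a full size, since compound 1 is known only by a limit: the limit of > 100000 nM in this assay, at which 1 of the 4 values shown sits.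

The compounds shown leave open whether the outcome at this ring carbon follows the ring itself or the nitrogen within it, a question that a cyclohexyl or a morpholin-4-yl group in the same place would bear on. They also leave open whether the order of these three groups would hold on a longer chain, with the piperidine ring set further along from the oxygen on the aromatic ring.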